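Series notes: aryl substituent change from compound 2 to compound 4

The compounds below may be only part of what the source reports. "The series", "measured", "known", "first", "only" and "open" are said of these compounds alone.

Of the compounds shown here, three of the shared core have been measured in an assay on isolated protein for inhibition of Indoleamine 2,3-dioxygenase 1 (Homo sapiens), read by spectrophotometry; on this read-out higher numbers stand for weaker inhibition and lower numbers for stronger inhibition. Compound 1 `O/N=C(/Nc1ccc(Cl)cc1)c1ccc2occc2c1` gives only a limit in this assay, > 30000 nM. Compound 3 `Cc1ccc(N/C(=N/O)c2ccc3occc3c2)cc1C` likewise gives only a limit in this assay, > 30000 nM. For the measured compounds named here, compound 2 `O/N=C(/Nc1cccc(F)c1)c1ccc2occc2c1` is the one member with a number: in this assay compound 2 gives 32700 nM. That number sits close to the limit of > 30000 nM in this assay, at which 2 of the 3 values shown sit. Going by the values given here, no pair among the measured compounds differs in a single place, so no measured step can be drawn. Compound 4 `O/N=C(/Nc1cccc(COc2ccccc2)c1)c1ccc2occc2c1` differs from compound 2 by phenoxymethyl in place of fluoro on an aromatic carbon. Compound 4 is expected to show a modest step toward stronger inhibition in this assay, a 2.2-fold lower number from compound 2 to compound 4 (0.34 log units; beyond the scatter). Compound 4 is thus estimated at 15000 nM in this assay, within a range from 3000 nM to 60000 nM, with a fair chance that only a limit is returned.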

Compound 4, half-maximal inhibitory concentration: > 30000 nM
Compound 4 ended at the assay's limit (the forecaster's own chance of this, stated with the estimate: 35%); at least 2.0-fold (0.30 log units) between middle value and limit.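

Compound 4 returned only a limit in this assay, so the step from compound 2 to compound 4 cannot be read: the limit of > 30000 nM in this assay, at which 3 of the 4 values shown sit.

The compounds shown leave open whether phenoxymethyl in place of fluoro strengthens or weakens inhibition, and by how much.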